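This account rests on a few compounds, and the source may have more. Where it says the series, first, only, none or still open, it means among the compounds named here.

The study concerns four compounds that share a branched, unsaturated side chain fixed to an aromatic ring, and it follows them in a functional assay on NALM-6 cells (Homo sapiens) for cytotoxicity, with a stated time of 72 h; on this read-out higher numbers stand for an effect only at larger amounts of compound and lower numbers for an effect already at smaller amounts.

Compound 1 `C=C[C@@](C)(/C=C/c1ccc(O)c(/C=C/c2ccc(Cl)cc2)c1)CCC=C(C)C` carries a hydroxy-bearing ring joined to a 4-chlorophenyl group through a two-carbon linker. In this assay compound 1 gives > 43400 nM, which is a limit of the measurement and not a number. Compound 2 `C=C[C@@](C)(/C=C/c1ccc(O)c(/C=C/c2ccc(Cl)c(Cl)c2)c1)CCC=C(C)C` differs from compound 1 in one place, (chloro in place of hydrogen on an aromatic carbon), and in this assay compound 2 gives 7510 nM. That single change yields an at least 5.7-fold lower number from compound 1 to compound 2 (0.76 log units; beyond the scatter).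

Compound 3 `C=C[C@@](C)(/C=C/c1ccc(-c2ccc(Cl)cc2)cc1)CCC=C(C)C` has a different core, in which the 4-chlorophenyl group sits directly on the central ring and no hydroxy group is present; the difference between the two cores is not broken down here. In this assay compound 3 gives > 43400 nM, a limit rather than a number, and because of the limit of > 43400 nM in this assay, at which 2 of the 3 values shown sit, the starting point for compound 3 is known only as that boundary.

Compound 4 `C=C[C@@](C)(/C=C/c1ccc(-c2ccc(Cl)c(Cl)c2)cc1)CCC=C(C)C` is related to compound 3 by the same change, (chloro in place of hydrogen on an aromatic carbon), and has not yet been measured. He expects the step in this assay to be an at least 2.1-fold lower number from compound 3 to compound 4 (0.33 log units; beyond the scatter), resting on the step of an at least 5.7-fold lower number from compound 1 to compound 2 (0.76 log units; beyond the scatter) seen on the first core. His estimate for compound 4 in this assay is therefore 20000 nM, with a range from 7000 nM to 60000 nM.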

Compound 4, half-maximal effective concentration: > 43400 nM
Compound 4: only a limit was reported; the forecaster's own chance of this, stated with the estimate: 40%; middle value at least 2.1-fold (0.33 log units) away from the limit.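

In this assay compound 4 gives > 43400 nM, which is a limit and not a number. Compound 3 stands at a limit as well, so no step can be read between compound 3 and compound 4: the limit of > 43400 nM in this assay, at which 3 of the 4 values shown sit.

The compounds shown leave open whether going from 4-chlorophenyl to 3,4-dichlorophenyl changes the read-out at all on the core of compound 3.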